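Thiazolyl Sulfonamide Replaces Methylisoxazolyl on a Shared Core

The compounds below may be only part of what the source reports. "The series", "measured", "known", "first", "only" and "open" are said of these compounds alone.

Three compounds share one core, a thiourea linking a trifluoromethyl-bearing bicyclic amine to a benzenesulfonamide, and differ only in what sits on the sulfonamide nitrogen. Compound 1, `CC(=O)NS(=O)(=O)c1ccc(N/C(S)=N\c2ccnc3cc(C(F)(F)F)ccc23)cc1`, carries an acetyl there and is the only one with a numeric result: in a functional assay on LoVo cells (Homo sapiens) for antiproliferative activity, read by sulforhodamine B assay, with a stated time of 48 h (a lower number here means a stronger inhibitor, a higher number a weaker inhibitor), compound 1 gives 30000 nM, a weak inhibitor. Within the data shown here, compound 2, `Cc1cc(NS(=O)(=O)c2ccc(N/C(S)=N\c3ccnc4cc(C(F)(F)F)ccc34)cc2)on1`, carries a 3-methyl-1,2-oxazol-5-yl; in this assay compound 2 gives "not active" (no number reported), with no number behind it, so compound 2 stands nowhere on the numeric scale and no step from compound 1 can be stated. Compound 3, `O=S(=O)(Nc1nccs1)c1ccc(N/C(S)=N\c2ccnc3cc(C(F)(F)F)ccc23)cc1`, is the next member: 1,3-thiazol-2-yl in place of 3-methyl-1,2-oxazol-5-yl on a sulfonamide nitrogen. Nothing measured here separates the two heteroaryl sulfonamides, and compound 2 offers no number to step from. The expectation for compound 3 in this assay is therefore weak activity in the region of compound 1 or none at all. Compound 3 is estimated at 30000 nM, within 10000 nM to 100000 nM, with a considerable chance that only a limit is reported.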

Compound 3, half-maximal inhibitory concentration: 67100 nM
Estimate against measurement, compound 3: 2.2-fold (0.35 log units) below; low and high end bracket the measured number.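

In this assay, 1,3-thiazol-2-yl gives this sulfonamide nitrogen its second numeric result, and replacing acetyl with it produces a 2.2-fold higher number from compound 1 to compound 3 (0.35 log units; beyond the scatter), a modest weakening that lies beyond the scatter. Among these compounds, the change from 3-methyl-1,2-oxazol-5-yl to 1,3-thiazol-2-yl cannot be read as a step, as compound 2 has no number; the record shows only that compound 3 gives a measured value while compound 2 is reported as "not active". Nothing measured here accounts for the difference between compound 1 and compound 3.

Both numeric results are weak, so the compounds shown leave open whether any group on this nitrogen can bring the shared core into a stronger range of antiproliferative activity. Going by these compounds, it also remains open how a free amino hydrogen in place of the acetyl, a longer acyl chain such as butanoyl, or a six-membered pyridin-2-yl would compare with acetyl and 1,3-thiazol-2-yl at this position.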